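From 2-chlorophenyl to 4-chlorophenyl in the series

A few compounds are considered here, and "the series" means these few. Any claim that something is new, unique, unknown or untested is made for them only; others in the source may bear on it.

In a functional assay on K562 cells (Homo sapiens) for antiproliferative activity, read by MTT assay, with a stated time of 48 h (on this read-out lower numbers stand for stronger inhibition and higher numbers for weaker inhibition), compound 1 `O=C(CCCCCn1cc(Nc2ncc(Cl)c(Nc3ccc(Cl)cc3)n2)cn1)NO` gives 490 nM and compound 2 `O=C(CCCCCCn1cc(Nc2ncc(Cl)c(Nc3ccccc3Cl)n2)cn1)NO` gives 860 nM so these two values lie within the scatter of each other. Among the measured compounds shown here, compound 2 therefore stands level with compound 1 on the numbers so far, and no measured pair yet isolates a single structural change.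

The next compound is compound 3 `O=C(CCCCCCn1cc(Nc2ncc(Cl)c(Nc3ccc(Cl)cc3)n2)cn1)NO` which carries 4-chlorophenyl in place of 2-chlorophenyl on a nitrogen on an aromatic ring while the rest of compound 2 stays as it is. For the measured compounds named here, the only guide is thin. Compound 1 also carries 4-chlorophenyl at that place and gives 490 nM in this assay but this is a single value, and it does not stand apart from that of compound 2 beyond the scatter. A small move toward a lower number is therefore expected, with no step beyond the scatter as the likeliest reading. The estimated change is a 1.4-fold lower number from compound 2 to compound 3 (0.16 log units; within the scatter) in this read-out. Compound 3 is estimated at 600 nM with an expected range of 250 nM to 1400 nM in this assay once measured.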

Compound 3, half-maximal inhibitory concentration: 320 nM
Beside the measured number, compound 3's estimate is 1.9-fold (0.27 log units) above it; low and high end bracket the measured number.
By their numbers in this assay, from the lowest: compounds 3, 1 and 2 (each within the scatter of the next, the first and the last beyond it).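

Working notes on the series: in this assay, putting 4-chlorophenyl in place of 2-chlorophenyl on a nitrogen on an aromatic ring gives a 2.7-fold lower number from compound 2 to compound 3 (0.43 log units; beyond the scatter) as the first step in the series that isolates one structural change, and it shows that this position responds to where the chlorine stands on the phenyl group, with the two groups sharing the same atoms joined differently. With 4-chlorophenyl held constant, (hydroxycarbamoyl)methyl in place of hydroxycarbamoyl on a saturated chain carbon gives a 1.5-fold lower number from compound 1 to compound 3 (0.19 log units; within the scatter) and so leaves this chain change unresolved in this assay on the values in hand. Nothing measured here bears on the reason for the step at the phenyl position.

Open, on these data alone, is how 3-chlorophenyl or 4-methoxyphenyl would read at this position, and whether a longer chain ending in hydroxycarbamoyl would stand apart from compound 3 beyond the scatter. Also open, as far as these compounds go, is whether the exchange of 2-chlorophenyl for 4-chlorophenyl would give a step of similar size on the chain of compound 1, as a single step says nothing about other chains.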